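Swapping the aryl group on the central chain of compound 2

The source may report more compounds than this note shows. Statements on the series, on what has been measured and on what is new or still open speak of the compounds shown alone.

Two compounds stand measured here. Compound 1 `COc1ccc(OC)c(/C=C/C(=O)/C=C(O)/C=C/c2cc(OC)ccc2OC)c1` is the weaker of the pair: in a functional assay on A549 cells (Homo sapiens) for antiproliferative activity, read by sulforhodamine B assay, with a stated time of 48 h (on this read-out higher numbers stand for weaker inhibition and lower numbers for stronger inhibition), compound 1 gives 16300 nM. Compound 2 `COc1cc(OC)c(C=C(C(=O)/C=C/c2cccc(OC)c2OC)C(=O)/C=C/c2cccc(OC)c2OC)c(OC)c1` has the lowest of the two numbers; in this assay compound 2 gives 630 nM, and the gap between the two values lies well beyond the usual scatter. Among the measured compounds shown here, no step between measured compounds that differ in one place exists in this set, so the direction of any single change must be judged from the structures alone.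

Compound 3 `COc1ccc(C=C(C(=O)/C=C/c2cccc(OC)c2OC)C(=O)/C=C/c2cccc(OC)c2OC)cc1O` is not yet measured. It differs from compound 2 in one place: 3-hydroxy-4-methoxyphenyl in place of 2,4,6-trimethoxyphenyl on a double-bonded chain carbon bound to a double-bonded chain carbon. Because compound 2 gives 630 nM, compound 3 is expected to stay in a nearby region, with a modest step toward a weaker inhibition or none beyond the scatter, estimated as a 1.6-fold higher number from compound 2 to compound 3 (0.20 log units; within the scatter). The estimate for compound 3 in this assay is 1000 nM, within 300 nM to 4000 nM.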

Compound 3, half-maximal inhibitory concentration: 270 nM
Beside the measured number, compound 3's estimate is 3.7-fold (0.57 log units) above it; measured number below the stated range.
By their numbers in this assay, from the lowest: compound 3; then compound 2; then compound 1.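

Among the compounds shown here, the swap of 2,4,6-trimethoxyphenyl for 3-hydroxy-4-methoxyphenyl on a double-bonded chain carbon bound to a double-bonded chain carbon gives the first single-place step in this set, with a 2.3-fold lower number from compound 2 to compound 3 (0.37 log units; beyond the scatter) in this assay and a change that is modest but beyond the scatter. It shows that this position accepts a different aryl group without any loss of inhibition, and that here the group with 9 heavy atoms and 1 hydrogen-bond donor goes with the lower number, against 12 heavy atoms and 0 hydrogen-bond donors for the group it replaces. No measurement at hand explains this step.

The compounds shown leave open whether the hydroxy group or the methoxy group of the entering ring carries the step. They also leave open how an amine or a carboxylic acid in that ring would fare in its place.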